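From a phenyl amine to an azetidine on one core

The compounds below may be only part of what the source reports. "The series", "measured", "known", "first", "only" and "open" are said of these compounds alone.

Measured in a functional assay on MCF7 cells (Homo sapiens) for inhibition, read by sulforhodamine B assay; a higher number here means a weaker inhibitor, a lower number a stronger inhibitor:
- compound 1 `O=C1C(Nc2ccccc2F)=CC(=O)c2c1nc1n2[C@H]2OC[C@@H](O)[C@H]2OC1`: > 4000 nM, a limit of the assay and not a number
- compound 2 `Cc1ccc(NC2=CC(=O)c3c(nc4n3[C@H]3OC[C@@H](O)[C@H]3OC4)C2=O)cc1C`: 4950 nM
- compound 3 `COc1ccccc1NC1=CC(=O)c2c(nc3n2[C@H]2OC[C@@H](O)[C@H]2OC3)C1=O`: 6580 nM

Compound 3, at 6580 nM in this assay, cannot be told apart from compound 2, since a 1.3-fold higher number from compound 2 to compound 3 (0.12 log units; within the scatter). Compound 4 `O=C1C(N2CCC2)=CC(=O)c2c1nc1n2[C@H]2OC[C@@H](O)[C@H]2OC1` keeps the shared core but has azetidin-1-yl in place of (2-methoxyphenyl)amino on a double-bonded ring carbon.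

Within the data shown here, three measured steps touch this position, and all of them swap one aromatic amine for another. Among the measured compounds shown here, the one readable step is the one just given, a 1.3-fold higher number from compound 2 to compound 3 (0.12 log units; within the scatter), and it suggests that this assay changes little between those two groups. The other two give no size: a step that the limit leaves unreadable from compound 1 to compound 2, and a step that the limit leaves unreadable from compound 1 to compound 3. For the measured compounds named here, no measured compound loses the aromatic ring or the amine hydrogen, so the data offer no direct guide to this larger change. No direction can be argued, and the safest expectation is a step no larger than the scatter, held with wide uncertainty. The expected change is a 1.3-fold lower number from compound 3 to compound 4 (0.12 log units; within the scatter). For compound 4 the estimated value is 5000 nM. The expected range for compound 4 runs from 1500 nM to 15000 nM.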

Compound 4, half-maximal inhibitory concentration: > 16000 nM
Compound 4 gave a limit, no number (the forecaster's own chance of this, stated with the estimate: 30%); middle value at least 3.2-fold (0.50 log units) from the limit.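

Compound 4 gives a limit of the assay and not a number: the limit of > 16000 nM in this assay, at which 1 of the 4 values shown sits. In this assay, among these compounds, putting azetidin-1-yl on the double-bonded ring carbon gives an at least 2.4-fold higher number from compound 3 to compound 4 (0.38 log units; beyond the scatter) and an at least 3.2-fold higher number from compound 2 to compound 4 (0.50 log units; beyond the scatter) and so yields the first readable steps at this position that lie beyond the scatter. The earlier readable step only exchanged one aromatic amine for another, whereas this change shows that the position is not indifferent to its group, since the smaller ring without an aromatic ring or an amine hydrogen leaves a weaker inhibitor than compound 2 or compound 3.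

Compound 1 also gives a limit and not a number, so none of its steps to the other compounds can be read: the limit of > 4000 nM in this assay, at which 1 of the 4 values shown sits. Azetidin-1-yl removes the aromatic ring and the amine hydrogen in one change, so the compounds shown cannot separate the two, and it stays open how cyclobutylamino, which has an amine hydrogen but no aromatic ring, or N-methyl-N-phenylamino, which has an aromatic ring but no amine hydrogen, would read in this assay.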